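Swapping the aryl on the pyrazole nitrogen for tert-butyl

The source may report more compounds than this note shows. Statements on the series, on what has been measured and on what is new or still open speak of the compounds shown alone.

Three ureas have been read in an assay on isolated protein for inhibition of STE20-like serine/threonine-protein kinase (Homo sapiens), read by thermal shift assay, tested at 10 uM; a lower number here means that the compound stabilises the target less, a higher number that the compound stabilises the target more against heat. Compound 1 `Cc1ccc(-n2nc(C(C)(C)C)cc2NC(=O)Nc2cc(C(F)(F)F)cc(C(F)(F)F)c2)cc1` gives 0 degrees C, compound 2 `Cn1nc(-c2ccccc2)cc1NC(=O)Nc1cc(C(F)(F)F)cc(C(F)(F)F)c1` gives 1.9 degrees C, and compound 3 `Cc1ccc(-n2nc(C(C)(C)C)cc2NC(=O)Nc2cc(F)cc(F)c2)cc1` gives 2.8 degrees C. Compound 3 thus holds the highest of the three numbers, though its gap to compound 2 lies within the scatter, while its gap to compound 1 lies beyond it. Compound 4 `CC(C)(C)c1cc(NC(=O)Nc2cc(F)cc(F)c2)n(C(C)(C)C)n1` differs from compound 3 in one place: tert-butyl in place of 4-methylphenyl on an aromatic nitrogen. Going by the values given here, no measured pair shows such a change, so the expected step from compound 3 to compound 4 is small, a number 0.80 degrees C lower from compound 3 to compound 4 (within the scatter), not clearly beyond the scatter. In this assay compound 4 is expected to give about 2 degrees C, with a range from 0 degrees C to 4 degrees C.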

Compound 4, shift of the target's melting temperature: 0.2 degrees C
For compound 4 the middle estimate is 1.8 degrees C above the measured one, and the stated range covers the measured number.
By their numbers in this assay, from the lowest: compounds 1 and 4 (each within the scatter of the next); then compounds 2 and 3 (each within the scatter of the next).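

In this assay, tert-butyl in place of 4-methylphenyl on an aromatic nitrogen gives a number 2.6 degrees C lower from compound 3 to compound 4 (beyond the scatter). Going by these compounds alone, this is the first comparison in the set that changes one place only, and it shows that this position responds to the change, with the rest of the molecule held fixed. Nothing measured here bears on why the step arises. Still open, from the compounds shown here alone, is whether cyclohexyl or a pyridine ring on this nitrogen would behave like 4-methylphenyl or like tert-butyl. The same swap also remains unread alongside the two trifluoromethyl groups of compound 1.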